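Removing the nitrile from an amide-linked kinase inhibitor

The compounds below may be only part of what the source reports. "The series", "measured", "known", "first", "only" and "open" are said of these compounds alone.

Among the measured compounds shown here, of the two compounds measured so far, compound 2 `N#Cc1cc(C(NC(=O)c2ccc3cnccc3c2)C2CCNCC2)ccc1Cl` stands at the lower number in an assay on isolated protein for inhibition of RAC-alpha serine/threonine-protein kinase (Homo sapiens); a lower number here means a stronger inhibitor, a higher number a weaker inhibitor: compound 2 gives 80 nM, whereas compound 1 `O=C(NC(c1ccc(F)c(F)c1)C1CCNCC1)c1ccc2cnccc2c1` gives 2680 nM. For the measured compounds named here, the single measured step, a 34-fold lower number from compound 1 to compound 2 (1.53 log units; beyond the scatter), exchanged the whole aryl group in one move, so the chloro and the cyano arrived together and their separate shares in that gain cannot be read off. Compound 3 `O=C(NC(c1ccc(Cl)cc1)C1CCNCC1)c1ccc2cnccc2c1` differs from compound 2 in one place: hydrogen in place of cyano on an aromatic carbon. This removes one of the two groups that arrived in the measured step while the chloro stays in place. Going by the values given here, no measured pair isolates the cyano alone, so the expectation rests on the size of that one step and on the assumption that each group carried some part of it. Compound 3 is therefore expected to be a weaker inhibitor than compound 2, but not to fall all the way back. Compound 3 is estimated at about 400 nM in this assay, within a range from 120 nM to 1500 nM. That estimate implies an expected step of a 5.0-fold higher number from compound 2 to compound 3 (0.70 log units; beyond the scatter).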

Compound 3, half-maximal inhibitory concentration: 190 nM
Compound 3: middle estimate off by 2.1-fold (0.32 log units), on the high side; measured number inside the range.
By their numbers in this assay, from the lowest: compound 2; then compound 3; then compound 1.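

In this assay the nitrile turns out to hold the smaller share of the earlier gain: taking it off gives a 2.4-fold higher number from compound 2 to compound 3 (0.38 log units; beyond the scatter), a modest step but still beyond the scatter, set against a 34-fold lower number from compound 1 to compound 2 (1.53 log units; beyond the scatter) for the whole aryl exchange. The 4-chlorophenyl group with no nitrile already gives a 14-fold lower number from compound 1 to compound 3 (1.15 log units; beyond the scatter), so most of the gain survives the loss of the nitrile, although that step also removes both fluoro groups and cannot be credited to the chloro alone. Nothing measured here explains why either group changes the number.

The compounds shown leave open whether the step belongs to the nitrile itself or whether a methyl or a methoxy group on the same aromatic carbon, ortho to the chloro group, would give a similar number. They also leave open whether the nitrile would give a step of this size on a ring with no chloro group, or whether a bromo group in place of the chloro would keep the gain.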